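Amide substituent variation on the shared core, fourth analogue

The source may report more compounds than this note shows. Statements on the series, on what has been measured and on what is new or still open speak of the compounds shown alone.

Compound 1 `O=C(C1CC12CCC2)N1CCc2nc(C#Cc3ccccc3)sc2C1`, compound 2 `CC1CC(C(=O)N2CCc3nc(C#Cc4ccccc4)sc3C2)C1` and compound 3 `COC1CC(C(=O)N2CCc3nc(C#Cc4ccccc4)sc3C2)C1` share one core and differ only in the group on the carbonyl carbon. In an assay on HEK293 cells for negative allosteric modulation of metabotropic glutamate receptor 5 (Homo sapiens), read by FLIPR, with a stated time of 1 h (on this read-out lower numbers stand for stronger inhibition and higher numbers for weaker inhibition), compound 1 returns > 10000 nM, which is a limit of the assay and not a number. Compound 2 likewise sits at the limit > 10000 nM in this assay. Compound 3 also gives only the limit > 10000 nM in this assay. Accordingly the steps a step that the two limits leave unreadable from compound 1 to compound 2, a step that the two limits leave unreadable from compound 1 to compound 3 and a step that the two limits leave unreadable from compound 2 to compound 3 cannot be read; every value shown sits at the limit of > 10000 nM in this assay, at which 3 of the 3 values shown sit. Compound 3 therefore stands at the limit alongside the two other compounds, with no number to place it higher or lower.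

Compound 4 `O=C(C1CCC(F)(F)CC1)N1CCc2nc(C#Cc3ccccc3)sc2C1` has not yet been measured. It differs from compound 3 by 4,4-difluorocyclohexyl in place of 3-methoxycyclobutyl on a carbonyl carbon. The measured steps that bear on this change are the three exchanges at the carbonyl carbon, and none of them is readable, so neither a direction nor a size can be drawn from them for this assay. Compound 4 is expected to stay near the limit, with an estimate of 20000 nM in a range from 5000 nM to 100000 nM. This estimate corresponds to an expected step that the limit leaves unreadable from compound 3 to compound 4.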

Compound 4, half-maximal inhibitory concentration: > 10000 nM
Compound 4 was reported as a limit (the forecaster's own chance of this, stated with the estimate: 75%); the middle value is on the limit's open side.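

Among these compounds, compound 4 gives > 10000 nM in this assay, which is a limit of the assay and not a number, so no step from compound 1, compound 2 or compound 3 to compound 4 can be read: the limit of > 10000 nM in this assay, at which 4 of the 4 values shown sit. The compounds shown leave open whether any group on the carbonyl carbon of the shared core gives a measurable value in this assay, and how these four groups rank against one another.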